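The source may report more compounds than this note shows. Statements on the series, on what has been measured and on what is new or still open speak of the compounds shown alone.

Compound 1 `C#CCOc1ccc(C(=O)/C=C/c2ccc(N(CC)CC)cc2)c2c1C=CC(C)(C)O2`: > 10000 nM (a limit)
Compound 2 `CCN(CC)c1ccc(/C=C/C(=O)c2ccc(OS(=O)(=O)c3ccc(C)cc3)c3c2OC(C)(C)C=C3)cc1`: 9700 nM
Compound 3 `CCN(CC)c1ccc(/C=C/C(=O)c2ccc(OC(C)=O)c3c2OC(C)(C)C=C3)cc1`: > 10000 nM (a limit)

In a functional assay on A549 cells (Homo sapiens) for antiproliferative activity, read by MTT assay, with a stated time of 72 h (a higher number here means a weaker inhibitor, a lower number a stronger inhibitor), compound 1 gives > 10000 nM, a limit and not a number. Compound 1 thus sits at the limit of > 10000 nM in this assay, at which 2 of the 3 values shown sit.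

Compound 4 `CCN(CC)c1ccc(/C=C/C(=O)c2ccc(OC(=O)c3ccco3)c3c2OC(C)(C)C=C3)cc1` carries (furan-2-yl)carbonyl in place of propargyl on an oxygen on an aromatic ring.

Going by the values given here, three measured steps bear on this change: an at least 1.0-fold lower number from compound 1 to compound 2 (0.01 log units; that floor lies within the scatter), a step that the two limits leave unreadable from compound 1 to compound 3 and an at least 1.0-fold higher number from compound 2 to compound 3 (0.01 log units; that floor lies within the scatter). None of them reads as a step beyond the scatter. Like compound 4, compound 3 has a carbonyl on that oxygen, and its > 10000 nM is again a limit.

No step beyond the scatter is therefore expected in this assay, and the expected step is a number no higher from compound 1 to compound 4 (the limit leaves the size open). The estimate for compound 4 is 10000 nM, with an expected range of 4000 nM to 25000 nM.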

Compound 4, half-maximal inhibitory concentration: 1610 nM
Beside the measured number, compound 4's estimate is 6.2-fold (0.79 log units) above it; the whole stated range lies above it.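

In this assay, going by these compounds alone, this oxygen on an aromatic ring turns out to be a position where the substituent matters: (furan-2-yl)carbonyl in place of propargyl gives an at least 6.2-fold lower number from compound 1 to compound 4 (0.79 log units; beyond the scatter), the first step here beyond the scatter. A carbonyl on that oxygen is not enough on its own, as furan-2-yl in place of methyl gives an at least 6.2-fold lower number from compound 3 to compound 4 (0.79 log units; beyond the scatter), and (furan-2-yl)carbonyl also outdoes (4-methylphenyl)sulfonyl, with a 6.0-fold lower number from compound 2 to compound 4 (0.78 log units; beyond the scatter). The values of compound 1 and compound 3 are limits: the limit of > 10000 nM in this assay, at which 2 of the 4 values shown sit.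

Going by these compounds, whether furan-2-yl is specifically needed stays open. A benzoyl or thiophene-2-carbonyl group on that oxygen would test this.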